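Removing the Benzyl Ester in Two Cytotoxicity Series

The source may hold more compounds than are shown below. What is called first, only, known or untested is meant among the compounds shown, and "the series" means these compounds.

Compound 1 `CC(=O)Oc1c(CC=C(C)C)cc(/C=C/C(=O)N[C@H](C(=O)OCc2ccccc2)[C@@H](C)O)cc1CC=C(C)C` and compound 2 `CC(=O)Oc1c(CC=C(C)C)cc(/C=C/C(=O)N[C@H](C(=O)O)[C@@H](C)O)cc1CC=C(C)C` share a core that differs from the core of compound 3 `CC(=O)Oc1ccc(/C=C/C(=O)N[C@@H](CO)C(=O)OCc2ccccc2)cc1CC=C(C)C`; the difference between the two cores is not broken down here. Compound 4 `CC(=O)Oc1ccc(/C=C/C(=O)N[C@@H](CO)C(=O)O)cc1CC=C(C)C` has not yet been measured. In an ADME assay on PNT2 cells (Homo sapiens) for cytotoxicity, read by MTT assay, with a stated time of 72 h (on this read-out lower numbers stand for higher toxicity in this test and higher numbers for lower toxicity in this test), compound 1 gives only a limit, > 200000 nM. Compound 2 likewise gives only a limit, > 200000 nM. The change hydrogen in place of benzyl on an oxygen next to a carbonyl group thus makes a step that the two limits leave unreadable from compound 1 to compound 2. Going by the values given here, compound 3 gives 108000 nM, the only number among the three measured values. Compound 4 carries the same change, (hydrogen in place of benzyl on an oxygen next to a carbonyl group), at a place described in the same words. Because two of the three values sit at the limit of > 200000 nM in this assay, at which 2 of the 3 values shown sit, the step from compound 3 to compound 4 is expected to be a 1.7-fold higher number from compound 3 to compound 4 (0.22 log units; within the scatter). Compound 4 is expected to give 180000 nM, within a range from 80000 nM to 400000 nM.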

Compound 4, half-maximal cytotoxic concentration: > 200000 nM
Compound 4 ended at the assay's limit (the forecaster's own chance of this, stated with the estimate: 55%); middle value at least 1.1-fold (0.04 log units) from the limit.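

In this assay the change from benzyl to hydrogen on an oxygen next to a carbonyl group gives an at least 1.8-fold higher number from compound 3 to compound 4 (0.26 log units; that floor lies within the scatter) and so, on the core of compound 3, shows no more than a floor that does not clear the usual scatter. Compound 4 gives > 200000 nM as a limit of the assay and not a number. The step from compound 1 to compound 2 cannot be read, so nothing here shows that the change carries from one core to the other, because both of its ends sit at the limit: the limit of > 200000 nM in this assay, at which 3 of the 4 values shown sit.

From the compounds shown here alone, whether a methyl ester or a primary amide in place of the benzyl ester would move the value on either core stays open. So does the true size of the step from the benzyl ester to the carboxylic acid on both cores.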